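The source may report more compounds than this note shows. Statements on the series, on what has been measured and on what is new or still open speak of the compounds shown alone.

Compound 1 `Cc1ccc(NC(=O)C2CCN(C/C=C/c3ccccc3)CC2)cc1` holds the second highest of the three numbers in a functional assay on A549 cells (Homo sapiens) for inhibition, read by MTT assay, with a stated time of 72 h (a lower number here means a stronger inhibitor, a higher number a weaker inhibitor), where compound 1 gives 29600 nM. Compound 2 `CC(C)c1ccc(NC(=O)C2CCN(C/C=C/c3ccccc3)CC2)cc1` gives 9430 nM, and compound 3 `COc1cccc(NC(=O)C2CCN(C/C=C/c3ccccc3)CC2)c1` gives 50500 nM. For the measured compounds named here, the only measured steps that swap the group on the amide-type nitrogen are a 1.7-fold higher number from compound 1 to compound 3 (0.23 log units; within the scatter) and a 5.4-fold higher number from compound 2 to compound 3 (0.73 log units; beyond the scatter). Compound 4 `O=C(Nc1ccccn1)C1CCN(C/C=C/c2ccccc2)CC1` differs from compound 1 by pyridin-2-yl in place of 4-methylphenyl on an amide-type nitrogen. Going by the values given here, no measured step replaces a carbon-only ring with a ring holding a nitrogen, so those two swaps are the nearest guide, and they point to a change no larger than modest. A small step is therefore expected, a 1.2-fold higher number from compound 1 to compound 4 (0.07 log units; within the scatter). The estimate for compound 4 is 35000 nM, within a range from 12000 nM to 100000 nM.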

Compound 4, half-maximal inhibitory concentration: 89300 nM
Beside the measured number, compound 4's estimate is 2.6-fold (0.41 log units) below it; the range from low to high includes it.
By their numbers in this assay, from the lowest: compound 2; then compounds 1, 3 and 4 (each within the scatter of the next, the first and the last beyond it).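

In this assay the first ring holding a nitrogen at this place, pyridin-2-yl, gives a 3.0-fold higher number from compound 1 to compound 4 (0.48 log units; beyond the scatter) and also a 9.5-fold higher number from compound 2 to compound 4 (0.98 log units; beyond the scatter) so a swap on the amide-type nitrogen can move the number beyond the scatter even without a carbon-only ring. The step of a 1.8-fold higher number from compound 3 to compound 4 (0.25 log units; within the scatter) leaves compound 3 and compound 4 not separated. For the compounds shown here, compound 2, with 4-isopropylphenyl, is the only compound whose steps to all the others lie beyond the scatter.

Nothing measured here bears on the reason for these differences. From the compounds shown here alone, whether pyridin-3-yl, or a pyridin-2-yl ring carrying an isopropyl group or an amine, would behave like compound 4 stays open.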